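Piperazinyl amide of the diaryl aminothiophene carboxamide series

A few compounds are considered here, and "the series" means these few. Any claim that something is new, unique, unknown or untested is made for them only; others in the source may bear on it.

Three members of the series have numbers in a functional assay on PC-3 cells (Homo sapiens) for inhibition, read by sulforhodamine B assay, with a stated time of 72 h; a higher number here means a weaker inhibitor, a lower number a stronger inhibitor. Compound 1 `Nc1sc(-c2ccc(Cl)cc2)c(-c2ccc(Cl)cc2)c1C(=O)NC1CCC(O)CC1` gives 5670 nM, compound 2 `CC(C)(C)NC(=O)c1c(N)sc(-c2ccc(Cl)cc2)c1-c1ccc(Cl)cc1` gives 15100 nM, and compound 3 `CCOC(=O)Nc1sc(-c2ccc(Cl)cc2)c(-c2ccc(Cl)cc2)c1C(=O)NC1CC1` gives 27600 nM. Among the compounds with values here, compound 2 thus stands second highest of the three: compound 3 is its nearest neighbour, within the scatter, and compound 1 its furthest, the only measured step that is defined by a single change, a 2.7-fold higher number from compound 1 to compound 2 (0.43 log units; beyond the scatter). Compound 3 differs from compound 1 in two places at once, so its value is reported without a step.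

Compound 4 `Nc1sc(-c2ccc(Cl)cc2)c(-c2ccc(Cl)cc2)c1C(=O)N1CCNCC1` is the next member to be tested. It departs from compound 2 at the carbonyl carbon: piperazin-1-yl in place of (tert-butyl)amino on a carbonyl carbon. Within the data shown here, the one step that bears on this is the exchange on the amide-type nitrogen from compound 1 to compound 2, where the ring-bearing group gave the lower number. Piperazin-1-yl again brings a ring, so the expected direction is a modest lowering, with the number for compound 4 likely to fall between those of compound 1 and compound 2, a 1.9-fold lower number from compound 2 to compound 4 (0.28 log units; within the scatter). Compound 4 is estimated at 8000 nM, with a range from 3000 nM to 25000 nM.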

Compound 4, half-maximal inhibitory concentration: 2710 nM
Beside the measured number, compound 4's estimate is 3.0-fold (0.47 log units) above it; measured number below the stated range.
By their numbers in this assay, from the lowest: compound 4; then compound 1; then compounds 2 and 3 (each within the scatter of the next).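

In this assay, within the data shown here, the substituent on the carbonyl carbon shifts the number further than the earlier compounds showed, with a 5.6-fold lower number from compound 2 to compound 4 (0.75 log units; beyond the scatter) for piperazin-1-yl in place of (tert-butyl)amino and a 2.1-fold lower number from compound 1 to compound 4 (0.32 log units; beyond the scatter) for piperazin-1-yl in place of (4-hydroxycyclohexyl)amino, both beyond the scatter. Since compound 1 also carries a ring on its amide nitrogen, the presence of a ring alone does not account for the lower number of compound 4; the second step separates two ring-bearing groups, a distinction the earlier step between compound 1 and compound 2 could not make. No measurement available here bears on why this exchange lowers the number.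

The compounds shown leave open whether the second ring nitrogen of piperazin-1-yl contributes, a question that morpholin-4-yl, piperidin-1-yl or 4-methylpiperazin-1-yl on the same carbonyl carbon would address. They also leave open whether the lower number of compound 4 survives when the free amino group of the shared core carries an ethoxycarbonyl group.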